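A few compounds are considered here, and "the series" means these few. Any claim that something is new, unique, unknown or untested is made for them only; others in the source may bear on it.

Of the compounds shown here, three built on a closely related core have been tested in an ADME assay on Vero cells (Chlorocebus sabaeus) for cytotoxicity, read by MTT assay, with a stated time of 72 h; a lower number here means a stronger inhibitor, a higher number a weaker inhibitor. Compound 1 `COc1cccc(OC)c1-c1nnc(-c2cc([N+](=O)[O-])cn2C)o1` gives 177000 nM in this assay. Compound 2 `COc1cc(/C=C/c2nnc(-c3cc([N+](=O)[O-])cn3C)o2)ccc1O` gives 203000 nM in this assay; its core differs from that of compound 1 in more than one place, and the difference between the two cores is not broken down here. Compound 3 `COc1cc(/C=C/c2nnc(-c3cc([N+](=O)[O-])c[nH]3)o2)ccc1O` gives 221000 nM in this assay. Compounds 2 and 3 differ in a single place: hydrogen in place of methyl on an aromatic nitrogen. That change produced a 1.1-fold higher number from compound 2 to compound 3 (0.04 log units; within the scatter), so the two compounds cannot be told apart within the usual scatter of repeated measurements. Among the compounds with values here, all three measured values lie close to one another, and no step between any pair of them is large enough to count as a real difference.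

Compound 4 `COc1cccc(OC)c1-c1nnc(-c2cc([N+](=O)[O-])c[nH]2)o1` has not yet been measured in this assay. It is related to compound 1 by the change (hydrogen in place of methyl on an aromatic nitrogen). The place of this change is described in exactly the same words for both pairs, so it is the same change made on a different core. Because the same change gave a 1.1-fold higher number from compound 2 to compound 3 (0.04 log units; within the scatter), the step from compound 1 to compound 4 is expected to be about a 1.1-fold higher number from compound 1 to compound 4 (0.04 log units; within the scatter). Compound 4 is therefore expected to give roughly 195000 nM in this assay, with the range from 110000 nM to 340000 nM covering the expected spread.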

Compound 4, half-maximal inhibitory concentration: 170000 nM
Compound 4: the middle estimate sits 1.1-fold (0.06 log units) above what was measured, and the stated range covers the measured number.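

Swapping the methyl on the aromatic nitrogen for hydrogen on the core of compound 1 gave a 1.0-fold lower number from compound 1 to compound 4 (0.02 log units; within the scatter) in this assay, so this pair cannot be told apart, just as the earlier pair on the other core could not. The two steps can be set side by side, and they do not differ: the same change on two cores in this assay, a 1.1-fold higher number (0.04 log units; within the scatter) from compound 2 to compound 3 and a 1.0-fold lower number (0.02 log units; within the scatter) from compound 1 to compound 4, 1.1-fold (0.05 log units) apart, within the scatter of two such steps

This shows that, on these two cores, the change carried over in the plainest way possible, with no measurable shift on either one. It does not show that the change would have so little effect on a different core or in a different assay, and two steps that are both within the scatter cannot reveal any smaller effect that the scatter might hide.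

The compounds shown leave open what a group other than hydrogen or methyl would do on that aromatic nitrogen, for example an ethyl group, a longer chain, or a chain ending in an amine or a carboxylic acid. They also leave open whether putting another group in place of the nitro group, such as a nitrile, would move the number in this assay.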